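The source may hold more compounds than are shown below. What is called first, only, known or untested is meant among the compounds shown, and "the series" means these compounds.

In a functional assay on the whole organism for antagonist activity, with Mus musculus as the target (on this read-out higher numbers stand for an effect only at larger amounts of compound and lower numbers for an effect already at smaller amounts), compound 1 `CCSc1nnc(-c2ccccc2F)n1C` gives 18.6 mg/kg and compound 2 `CCn1c(SC)nnc1-c1ccccc1F` gives 75 mg/kg. The result for compound 3 `CSc1nc(-c2ccccc2)nn1C` is only a limit of the assay, > 200 mg/kg, so it stands at the limit of > 200 mg/kg in this assay, at which 1 of the 3 values shown sits, and has no actual number. Compound 4 `Cn1nc(-c2ccccc2)nc1S(C)(=O)=O` has methylsulfonyl in place of methylsulfanyl on an aromatic carbon of compound 3, (methylsulfonyl in place of methylsulfanyl on an aromatic carbon). For the measured compounds named here, no measured step covers this exchange, so the expectation is loose and leans on compound 2 at 75 mg/kg, the higher of the two real numbers. The expected change is an at least 3.3-fold lower number from compound 3 to compound 4 (0.52 log units; beyond the scatter), a clear move toward smaller doses. For compound 4 the estimate is 60 mg/kg, with an expected range from 12 mg/kg to 200 mg/kg.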

Compound 4, dose for half-maximal effect: > 200 mg/kg
Compound 4 was reported as a limit (the forecaster's own chance of this, stated with the estimate: 35%); at least 3.3-fold (0.52 log units) between middle value and limit.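

Compound 3 and compound 4 both sit at a limit of the assay, so no step can be read between them: the limit of > 200 mg/kg in this assay, at which 2 of the 4 values shown sit.

As far as these compounds go, whether methylsulfonyl in place of methylsulfanyl on an aromatic carbon changes the effective dose at all stays open.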